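The compounds below may be only part of what the source reports. "The series", "measured", "known", "first", "only" and "open" are said of these compounds alone.

Measured in a functional assay on OVCAR-5 cells (Homo sapiens) for inhibition, read by colorimetric assay and sulforhodamine B assay, with a stated time of 48 h; on this read-out higher numbers stand for weaker inhibition of growth and lower numbers for stronger inhibition of growth:
- compound 1 `CCCCCCCCCCCC[C@@H](O)[C@H]1CC[C@H]([C@H](O)CCCCCCCCCCNC(=O)c2cccs2)O1`: 2510 nM
- compound 2 `CCCCCCCCCCCC[C@@H](O)[C@H]1CC[C@H]([C@H](O)CCCCCCCCCCNC(=O)c2cncs2)O1`: 100000 nM

Compound 1 has the lower of the two numbers in this assay, so it shows the stronger inhibition of growth of this pair. The open question is compound 3 `CCCCCCCCCCCC[C@@H](O)[C@H]1CC[C@H]([C@H](O)CCCCCCCCCCNC(=O)c2ccsc2)O1`, which keeps the core of compound 1 and changes only the ring on the amide carbonyl: thiophen-3-yl in place of thiophen-2-yl on a carbonyl carbon. In words, thiophen-3-yl stands in place of thiophen-2-yl on a carbonyl carbon.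

Among the compounds with values here, only one measured step bears on this change, and it sits at the same place: a 40-fold higher number from compound 1 to compound 2 (1.60 log units; beyond the scatter), a large step with 1,3-thiazol-5-yl in place of thiophen-2-yl. That single step shows the place can matter, but it establishes no pattern, and it brings in a different ring, whereas compound 3 stays a thiophene with the same atoms. A much smaller move in the same direction is therefore expected, possibly not beyond the scatter.

The expected step is a 1.6-fold higher number from compound 1 to compound 3 (0.20 log units; within the scatter).

For compound 3 the estimated value is 4000 nM, with an expected range of 1300 nM to 20000 nM.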

Compound 3, concentration for 50% growth inhibition: 2690 nM
Estimate against measurement, compound 3: 1.5-fold (0.17 log units) above; low and high end bracket the measured number.
By their numbers in this assay, from the lowest: compounds 1 and 3 (each within the scatter of the next); then compound 2.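

In this assay, thiophen-3-yl in place of thiophen-2-yl on a carbonyl carbon gives a step within the scatter (a 1.1-fold higher number from compound 1 to compound 3 (0.03 log units; within the scatter)), so the two thiophene attachments cannot be told apart at this place, with the rest of the molecule held constant. The large step from the thiazole to the second thiophene (a 37-fold lower number from compound 2 to compound 3 (1.57 log units; beyond the scatter)) shows that, among these three compounds, compound 2 alone stands apart, and that the gap first seen with 1,3-thiazol-5-yl does not extend to a mere change in how a thiophene is attached. No measurement at hand accounts for the gap between compound 2 and the two thiophene compounds.

Still open, from the compounds shown here alone, is whether the large step belongs to 1,3-thiazol-5-yl in particular or would also appear with other nitrogen-containing rings on the carbonyl carbon, such as pyridin-3-yl or 1,3-thiazol-2-yl, and whether a plain phenyl or furan-2-yl would stay with the thiophenes. Also open, going by these compounds, is whether the tolerance seen between the two thiophenes would hold with a shorter chain linking the amide nitrogen to the core of compound 1.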